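Replacing cyclohexyl on the shared core: notes toward compound 4

The source may hold more compounds than are shown below. What is called first, only, known or untested is meant among the compounds shown, and "the series" means these compounds.

Measured in an assay on isolated protein for inhibition of Aromatase (Homo sapiens), read by fluorescence and colorimetric assay, with a stated time of 30 min; on this read-out lower numbers stand for stronger inhibition and higher numbers for weaker inhibition:
compound 1 `N#Cc1ccc(C(c2ccc(C#N)cc2)n2cc(C3CCCCC3)nn2)cc1` gives 19300 nM
compound 2 `N#Cc1ccc(C(c2ccc(C#N)cc2)n2cc(COc3ccccc3)nn2)cc1` gives 11000 nM
compound 3 `N#Cc1ccc(C(c2ccc(C#N)cc2)n2cc(COc3ccc(Cl)cc3)nn2)cc1` gives 16100 nM

Compound 1 sits at the high end of the three numbers, yet a 1.2-fold lower number from compound 1 to compound 3 (0.08 log units; within the scatter) and a 1.8-fold lower number from compound 1 to compound 2 (0.24 log units; within the scatter) both lie within the scatter, so the three compounds are not separated by this assay.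

Compound 4 `N#Cc1ccc(OCc2cn(C(c3ccc(C#N)cc3)c3ccc(C#N)cc3)nn2)cc1` differs from compound 1 by (4-cyanophenoxy)methyl in place of cyclohexyl on an aromatic carbon. The measured steps that bear on this are the two earlier replacements of cyclohexyl, a 1.8-fold lower number from compound 1 to compound 2 (0.24 log units; within the scatter) and a 1.2-fold lower number from compound 1 to compound 3 (0.08 log units; within the scatter), and the substituent change on the phenoxy ring, a 1.5-fold higher number from compound 2 to compound 3 (0.17 log units; within the scatter); each is within the scatter. For the measured compounds named here, no measured pair shows a nitrile on the phenoxy ring, so nothing here predicts an effect beyond the scatter. Compound 4 is therefore expected to come out near the measured three, with a 1.5-fold lower number from compound 1 to compound 4 (0.17 log units; within the scatter) as the anticipated step in this assay. The estimate for compound 4 is 13000 nM, expected to fall between 6000 nM and 30000 nM.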

Compound 4, half-maximal inhibitory concentration: 4640 nM
Beside the measured number, compound 4's estimate is 2.8-fold (0.45 log units) above it; the measured number lies below the stated range.
By their numbers in this assay, from the lowest: compound 4; then compounds 2, 3 and 1 (each within the scatter of the next).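

In this assay, for the compounds shown here, the nitrile on the phenoxy ring is the first change in this group to separate compounds beyond the scatter: a 2.4-fold lower number from compound 2 to compound 4 (0.37 log units; beyond the scatter) for cyano in place of hydrogen and a 3.5-fold lower number from compound 3 to compound 4 (0.54 log units; beyond the scatter) for cyano in place of chloro, while hydrogen and chloro themselves were not separated. Replacing cyclohexyl now also gives a readable step, a 4.2-fold lower number from compound 1 to compound 4 (0.62 log units; beyond the scatter) for (4-cyanophenoxy)methyl, whereas the phenoxymethyl and (4-chlorophenoxy)methyl replacements stayed within the scatter. Nothing available here explains the difference made by the nitrile.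

Open, on these data alone, is whether this step is particular to the nitrile or also appears with a carboxylic acid, an amine or a methoxy group on the phenoxy ring. Also open, as far as these compounds go, is whether it survives moving the nitrile elsewhere on that ring or using a longer chain in place of the methyl link.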